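Weak growth inhibition in the N-acyl series

The source may report more compounds than this note shows. Statements on the series, on what has been measured and on what is new or still open speak of the compounds shown alone.

Measured in a functional assay on LNCaP cells (Homo sapiens) for inhibition, read by WST assay, with a stated time of 48 h; a higher number here means a weaker inhibitor of growth, a lower number a stronger inhibitor of growth
- compound 1 `C=C(C)C(=O)N(C)C(=O)/C=C/c1cc(OC)c(OC)c(OC)c1` gives > 10000 nM (a limit)
- compound 2 `C=C(C)C(=O)N(Cc1ccccc1C)C(=O)/C=C/c1cc(OC)c(OC)c(OC)c1` gives 10000 nM

Among the compounds with values here, compound 2 carries the only number in this assay so far. Compound 3 `C#CCN(C(=O)/C=C/c1cc(OC)c(OC)c(OC)c1)C(=O)C(=C)C` differs from it by ethynyl in place of 2-methylphenyl on a saturated chain carbon bound to an amide-type nitrogen. Only a number no higher from compound 1 to compound 2 (the limit leaves the size open) bears on this change, and its size cannot be read. The expected step is no change at the digits printed from compound 2 to compound 3 (within the scatter), with no change beyond the scatter. For compound 3 the estimated value is 10000 nM, with an expected range of 3000 nM to 30000 nM.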

Compound 3, concentration for 50% growth inhibition: > 10000 nM
Compound 3: only a limit was reported; the forecaster's own chance of this, stated with the estimate: 55%; the middle value lies on the limit itself.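

In this assay compound 3 gives > 10000 nM, which is a limit and not a number. Ethynyl in place of 2-methylphenyl, on a saturated chain carbon bound to an amide-type nitrogen, removes the ring and brings a number no lower from compound 2 to compound 3 (the limit leaves the size open). The sizes of the steps to compound 3 cannot be read. The series remains mostly at the assay limit: the limit of > 10000 nM in this assay, at which 2 of the 3 values shown sit.

On these data alone, with a single number, how far this position can shift growth inhibition stays open. An amine or a carboxylic acid at this place remains untested among the compounds shown here.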